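Thiosemicarbazones on a shared core: swapping piperidinyl for morpholinyl

The compounds below may be only part of what the source reports. "The series", "measured", "known", "first", "only" and "open" are said of these compounds alone.

Of the compounds shown here, three built on one shared core have been tested in a functional assay on K562 cells (Homo sapiens) for cytotoxicity, read by MTT assay, with a stated time of 72 h; a higher number here means a weaker inhibitor, a lower number a stronger inhibitor. Compound 1 `CC(C)NC(=S)N/N=C1\CC(c2ccc(O)cc2)Oc2cc(O)ccc21` gives 21300 nM in this assay. Compound 2 `CCCNC(=S)N/N=C1\CC(c2ccc(O)cc2)Oc2cc(O)ccc21` gives 31000 nM, and compound 3 `Oc1ccc(C2C/C(=N\NC(=S)N3CCCCC3)c3ccc(O)cc3O2)cc1` gives 13700 nM. These three differ only in the group attached to the thiocarbonyl carbon. The steps among them are small: a 1.5-fold higher number from compound 1 to compound 2 (0.16 log units; within the scatter), a 1.6-fold lower number from compound 1 to compound 3 (0.19 log units; within the scatter), and a 2.3-fold lower number from compound 2 to compound 3 (0.35 log units; beyond the scatter). Compound 3 holds the lowest of the three numbers; its gap to compound 1 lies within the scatter, while its gap to compound 2 is modest and beyond it.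

Compound 4 `Oc1ccc(C2C/C(=N\NC(=S)N3CCOCC3)c3ccc(O)cc3O2)cc1` keeps everything else in place and differs from compound 3 by one exchange: morpholin-4-yl in place of piperidin-1-yl on a thiocarbonyl carbon. For the measured compounds named here, the steps that bear on this exchange are those that vary the same position, and none of them moved the number by much. Three different groups on the thiocarbonyl carbon gave numbers that span only a modest range, so the expectation for a fourth group at that position is a step no larger than the scatter, in no settled direction.

Compound 4 is therefore expected to give about 16000 nM in this assay, estimated to fall between 7000 nM and 40000 nM, which would mean an expected step of a 1.2-fold higher number from compound 3 to compound 4 (0.07 log units; within the scatter).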

Compound 4, half-maximal inhibitory concentration: 29400 nM
Compound 4: middle estimate off by 1.8-fold (0.26 log units), on the low side; the range from low to high includes it.
By their numbers in this assay, from the lowest: compounds 3, 1, 4 and 2 (each within the scatter of the next, the first and the last beyond it).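

Replacing piperidin-1-yl with morpholin-4-yl on the thiocarbonyl carbon keeps the ring size and the count of heavy atoms, exchanging one ring carbon for an oxygen and adding one hydrogen-bond acceptor, yet in this assay the change gives a 2.1-fold higher number from compound 3 to compound 4 (0.33 log units; beyond the scatter) and so shows that a single atom exchange within this ring can produce a modest step. The morpholin-4-yl group shows no such separation from the two open-chain groups, with a 1.1-fold lower number from compound 2 to compound 4 (0.02 log units; within the scatter) for its exchange with propylamino and a 1.4-fold higher number from compound 1 to compound 4 (0.14 log units; within the scatter) for its exchange with isopropylamino on the same carbon. Nothing available here accounts for the step between the two rings.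

The compounds shown leave open whether this step belongs to the oxygen in particular or to any second hetero atom in the ring, a question that thiomorpholin-4-yl, with sulfur in that place, or piperazin-1-yl, with nitrogen, could address. They also leave open how a ring of another size would compare, such as the five-membered pyrrolidin-1-yl.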